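Quinoxaline Sulfones: Halogen Swap on a Hydroxypiperidine Analog

A few compounds are considered here, and "the series" means these few. Any claim that something is new, unique, unknown or untested is made for them only; others in the source may bear on it.

Measured compounds:
- compound 1, `O=S(=O)(c1ccc(Br)cc1)c1nc2ccccc2nc1N1CCCC1`: > 50000 nM
- compound 2, `O=S(=O)(c1ccc(F)cc1)c1nc2ccccc2nc1N1CCCC1`: 31100 nM
- compound 3, `O=S(=O)(c1ccc(Br)cc1)c1nc2ccccc2nc1N1CCCC(O)C1`: 2100 nM

Three compounds share one core and were tested in a functional assay on A549 cells (Homo sapiens) for cytotoxicity, read by MTT assay, with a stated time of 72 h; on this read-out higher numbers stand for weaker inhibition and lower numbers for stronger inhibition. For compound 1 the value of > 50000 nM is a limit of the assay, not a number (the limit of > 50000 nM in this assay, at which 1 of the 3 values shown sits). Compound 2 gives 31100 nM, and compound 3 gives 2100 nM, the lowest of the two numbers.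

Two changes link them. From compound 1 to compound 2 the change is fluoro in place of bromo on an aromatic carbon, and it brought an at least 1.6-fold lower number from compound 1 to compound 2 (0.20 log units; that floor lies within the scatter). From compound 1 to compound 3 the change is 3-hydroxypiperidin-1-yl in place of pyrrolidin-1-yl on an aromatic carbon, which brought an at least 23-fold lower number from compound 1 to compound 3 (1.37 log units; beyond the scatter).

Compound 4, `O=S(=O)(c1ccc(F)cc1)c1nc2ccccc2nc1N1CCCC(O)C1`, has not been measured. Within the data shown here, it differs from compound 3 by fluoro in place of bromo on an aromatic carbon, the same change as the one from compound 1 to compound 2, at the same place. Because that earlier step was an at least 1.6-fold lower number from compound 1 to compound 2 (0.20 log units; that floor lies within the scatter), only a modest shift is expected here, a 1.4-fold lower number from compound 3 to compound 4 (0.15 log units; within the scatter). Compound 4 is therefore estimated to give about 1500 nM in this assay, most likely between 500 nM and 6000 nM.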

Compound 4, half-maximal inhibitory concentration: 8170 nM
Beside the measured number, compound 4's estimate is 5.4-fold (0.74 log units) below it; measured number above the stated range.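

In this assay, fluoro in place of bromo with 3-hydroxypiperidin-1-yl on the shared core brought a 3.9-fold higher number from compound 3 to compound 4 (0.59 log units; beyond the scatter), so this change did not carry over at the same size, or in the same direction, from the pyrrolidin-1-yl pair: the same change on two cores in this assay, an at least 1.6-fold lower number (0.20 log units; that floor lies within the scatter) from compound 1 to compound 2 and a 3.9-fold higher number (0.59 log units; beyond the scatter) from compound 3 to compound 4, at least 6.2-fold (0.79 log units) apart, beyond the scatter of two such steps The other change, 3-hydroxypiperidin-1-yl in place of pyrrolidin-1-yl, brought a 3.8-fold lower number from compound 2 to compound 4 (0.58 log units; beyond the scatter), which is the same direction as with bromo but not the same size: the same change on two cores in this assay, an at least 23-fold lower number (1.37 log units; beyond the scatter) from compound 1 to compound 3 and a 3.8-fold lower number (0.58 log units; beyond the scatter) from compound 2 to compound 4, at least 6.2-fold (0.79 log units) apart, beyond the scatter of two such steps Compound 1 gives > 50000 nM, a limit of the assay and not a number, so the full size of its steps stays unread, and these pairs do not show why the steps differ.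

The compounds shown leave open how chloro or methoxy in that place on the phenyl ring would stand beside bromo and fluoro. Also open, going by these compounds, is whether a plain piperidin-1-yl or a morpholine ring would follow 3-hydroxypiperidin-1-yl or pyrrolidin-1-yl, which would help separate the hydroxy group from the larger ring.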